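The source may hold more compounds than are shown below. What is called first, only, known or untested is meant among the compounds shown, and "the series" means these compounds.

Compound 1 `CC1=CC[C@H](C(C)(C)N=C=S)CC1` opens the set and was tested in an ADME assay on Vero cells (Chlorocebus sabaeus) for inhibition, read by sulforhodamine B assay, with a stated time of 48 h; on this read-out higher numbers stand for weaker inhibition of growth and lower numbers for stronger inhibition of growth. In this assay compound 1 is reported only as a limit, > 100000 nM. For the measured compounds named here, compound 2 `CC1=CC[C@H](C(C)(C)NC(=S)N/N=C/c2ccccc2O)CC1` gives 11200 nM in this assay, and this is the only actual number among the two results, the other result being (the limit of > 100000 nM in this assay, at which 1 of the 2 values shown sits). Compound 3 `CC1=CC[C@H](C(C)(C)NC(=S)N/N=C/c2ccc(Cl)cc2)CC1` has not yet been measured in this assay. It differs from compound 2 in a single place: 4-chlorophenyl in place of 2-hydroxyphenyl on a carbon with a double bond to nitrogen. Going by the values given here, no pair of measured compounds shows what such an exchange does in this assay, so there is nothing to lean on beyond the two results given. The step from a 1.1-fold lower number from compound 2 to compound 3 (0.05 log units; within the scatter) is expected to stay within the usual scatter, with no clear direction. On that basis compound 3 is estimated at 10000 nM in this assay, with a range from 3000 nM to 40000 nM.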

Compound 3, concentration for total growth inhibition: > 100000 nM
Compound 3: only a limit was reported; the forecaster's own chance of this, stated with the estimate: 10%; middle value at least 10-fold (1.00 log units) away from the limit.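

In this assay, 4-chlorophenyl in place of 2-hydroxyphenyl on a carbon with a double bond to nitrogen gives an at least 8.9-fold higher number from compound 2 to compound 3 (0.95 log units; beyond the scatter), which shows that the read-out responds to the group at this place. Of the compounds shown, only compound 2, with 2-hydroxyphenyl, gives an actual number. The reading for compound 3 is a limit and not a number, so the full size of the step cannot be read, and the exchange brings compound 3 to the same limit as compound 1: the limit of > 100000 nM in this assay, at which 2 of the 3 values shown sit.

The compounds shown do not separate the loss of the hydroxyl from the arrival of the chlorine, and a plain phenyl would be needed to divide the two. They also leave open how an amine or a carboxylic acid on the phenyl ring would read.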